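Halogen Returns to the Aryl Ring, at a New Place

A few compounds are considered here, and "the series" means these few. Any claim that something is new, unique, unknown or untested is made for them only; others in the source may bear on it.

Three compounds share one core and differ only in the group on the aromatic ring. In a functional assay on the whole organism (strain Swiss) with Mus musculus as the target, in the maximal electroshock model, with a stated time of 1 h, at a dose of 300 mg/kg by the intraperitoneal route (on this read-out higher numbers stand for a stronger effect at the one dose given and lower numbers for a weaker effect), compound 3 `Cc1cccc(N2CCN(C(=O)C(C)N3C(=O)CCC3=O)CC2)c1` gives 0%, compound 1 `COc1cccc(N2CCN(C(=O)C(C)N3C(=O)CCC3=O)CC2)c1` gives 0%, and compound 2 `CC(C(=O)N1CCN(c2cccc(F)c2)CC1)N1C(=O)CCC1=O` gives 75%. The steps are stark: a number 75 percentage points higher from compound 1 to compound 2 (beyond the scatter), whereas no change at the digits printed from compound 1 to compound 3 (within the scatter) and a number 75 percentage points lower from compound 2 to compound 3 (beyond the scatter). Compound 3 thus stands level with compound 1, the two together at the bottom of the three, and furthest from compound 2.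

Compound 4 `CC(C(=O)N1CCN(c2ccccc2Cl)CC1)N1C(=O)CCC1=O` is the next step: 2-chlorophenyl in place of 3-methylphenyl on an amine nitrogen in a ring. The steps from compound 1 to compound 2 and from compound 2 to compound 3 both bear on it, each showing that the single halogen-bearing ring gave the whole of the measured effect. For the measured compounds named here, compound 4 brings a halogen back, but as chlorine rather than fluorine, and the 2-chlorophenyl places it differently from the fluoro ring of compound 2; no measured step covers either change. A rise is therefore expected, a number 40 percentage points higher from compound 3 to compound 4 (beyond the scatter), with wide uncertainty. Compound 4 is estimated at 40%, in the range 0% to 90%.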

Compound 4, a percentage reported as activity, at one dose (the size of the read-out at that dose, not a potency): 25%
The estimate for compound 4 lay 15 percentage points above the measured number; the range from low to high includes it.
By their numbers in this assay, from the lowest: compounds 1 and 3 (each within the scatter of the next); then compound 4; then compound 2.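

In this assay the 2-chlorophenyl group rises clear of the two rings without a halogen, with a number 25 percentage points higher from compound 3 to compound 4 (beyond the scatter) and a number 25 percentage points higher from compound 1 to compound 4 (beyond the scatter) on the same side, yet it falls well short of the 3-fluorophenyl group, with a number 50 percentage points lower from compound 2 to compound 4 (beyond the scatter) as the gap between the two halogen-bearing rings. The effect at this position is therefore not confined to the one fluoro ring, and a halogen on the ring does not by itself fix its size. No measurement given here explains why these rings differ.

Going by these compounds, with the halogen and its place on the ring changing together in this last step, the share of each in that gap remains open. On these data alone, how an unsubstituted phenyl, a bromophenyl or a trifluoromethylphenyl group would compare also remains open.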